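Aryl Ketone Variation on a Quinoline Enone Scaffold

The source may hold more compounds than are shown below. What is called first, only, known or untested is meant among the compounds shown, and "the series" means these compounds.

Compound 1, `COc1ccc(-c2cc3ccccc3nc2/C=C/C(=O)c2ccc([N+](=O)[O-])cc2)cc1`, gives 770 nM in a functional assay on NCI-H1299 cells (Homo sapiens) for antiproliferative activity, read by XTT assay, with a stated time of 72 h; a higher number here means a weaker inhibitor, a lower number a stronger inhibitor.
Compound 2, `COc1ccc(-c2cc3ccccc3nc2/C=C/C(=O)c2cccs2)cc1`, gives 720 nM.
Compound 3, `COc1ccc(-c2cc3ccccc3nc2/C=C/C(=O)c2ccccn2)cc1`, gives 660 nM.

Compound 3 gives the lowest of the three numbers, but its steps from the other two, a 1.2-fold lower number from compound 1 to compound 3 (0.07 log units; within the scatter) and a 1.1-fold lower number from compound 2 to compound 3 (0.04 log units; within the scatter), lie within the scatter, so no order among the three is claimed. Compound 4, `COc1ccc(-c2cc3ccccc3nc2/C=C/C(=O)c2cnc(N)nc2C)cc1`, differs from compound 3 by 2-amino-4-methylpyrimidin-5-yl in place of pyridin-2-yl on a carbonyl carbon. The measured steps that bear on this change are those at the same carbonyl carbon: a 1.1-fold lower number from compound 1 to compound 2 (0.03 log units; within the scatter), a 1.2-fold lower number from compound 1 to compound 3 (0.07 log units; within the scatter) and a 1.1-fold lower number from compound 2 to compound 3 (0.04 log units; within the scatter), each within the scatter. Among the measured compounds shown here, none of the measured groups at this position resembles the entering group closely, so the comparison is only partial. On the evidence of these three steps, no change beyond the scatter is expected in this assay for compound 4, and the expected step is a 1.1-fold higher number from compound 3 to compound 4 (0.03 log units; within the scatter). Compound 4 is therefore estimated at 700 nM, with a range from 300 nM to 1700 nM.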

Compound 4, half-maximal inhibitory concentration: > 10000 nM
Compound 4: a limit, no number; the forecaster's own chance of this, stated with the estimate: 5%; middle value at least 14-fold (1.15 log units) away from the limit.
By their numbers in this assay, from the lowest: compounds 3, 2 and 1 (each within the scatter of the next). At a limit, above all of these: compound 4.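

In this assay compound 4 gives > 10000 nM, which is a limit of the assay and not a number. The carbonyl carbon had shown no step beyond the scatter among 4-nitrophenyl, thiophen-2-yl and pyridin-2-yl, yet this position does not tolerate every aromatic ring: 2-amino-4-methylpyrimidin-5-yl gives an at least 15-fold higher number from compound 3 to compound 4 (1.18 log units; beyond the scatter), an at least 13-fold higher number from compound 2 to compound 4 (1.14 log units; beyond the scatter) and an at least 12-fold higher number from compound 1 to compound 4 (1.11 log units; beyond the scatter), each large and beyond the scatter. Compound 4 alone sits at this limit among the compounds shown: the limit of > 10000 nM in this assay, at which 1 of the 4 values shown sits.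

The entering group differs from pyridin-2-yl in its ring nitrogens, its amine and its methyl group at once, so the compounds shown do not tell which of these goes with the loss. On these data alone, whether a pyrimidin-5-yl ring carrying only the amine, only the methyl group or neither would behave like compound 4 remains open.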